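This account rests on a few compounds, and the source may have more. Where it says the series, first, only, none or still open, it means among the compounds named here.

Measured compounds:
Compound 1, `O=C(COc1ccc(C(=O)/C=C/c2ccccc2Cl)cc1)N[C@H]1CCOC1=O`: 4610 nM in a functional assay on PC-3 cells (Homo sapiens) for antiproliferative activity, read by MTT assay, with a stated time of 72 h; a lower number here means a stronger inhibitor, a higher number a weaker inhibitor.
Compound 2, `O=C(CNc1ccc(Cl)cc1Cl)N[C@H]1CCOC1=O`: in this assay compound 2 reaches only the limit > 64000 nM, not a number.
Compound 3, `O=C1OCC[C@@H]1NC(=S)SCCOc1ccc(Cl)cc1`: in this assay compound 3 likewise reaches only the limit > 64000 nM, not a number.

Within the data shown here, compound 1 thus carries the only numerical value in this assay; the other two values are limits, and two of the three values sit at the limit of > 64000 nM in this assay, at which 2 of the 3 values shown sit. Among the measured compounds shown here, no step between measured compounds that differ in one place is available, so nothing here tells how large a change a single substitution produces in this assay.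

Compound 4, `O=C(COc1ccc(C(=O)/C=C/c2ccc(F)cc2)cc1)N[C@H]1CCOC1=O`, has not yet been measured. It differs from compound 1 in one place: 4-fluorophenyl in place of 2-chlorophenyl on a double-bonded chain carbon bound to a double-bonded chain carbon. Both groups keep the same count of heavy atoms, the same ring type and no donors or acceptors. The account expects a small step, of no clear direction, within the usual scatter, that is a 1.1-fold higher number from compound 1 to compound 4 (0.04 log units; within the scatter). Compound 4 is therefore estimated at 5000 nM, with a range from 1500 nM to 16000 nM.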

Compound 4, half-maximal inhibitory concentration: 15600 nM
For compound 4 the middle estimate is 3.1-fold (0.49 log units) below the measured one, within the range that was stated.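

In this assay, 4-fluorophenyl in place of 2-chlorophenyl on a double-bonded chain carbon bound to a double-bonded chain carbon gives a 3.4-fold higher number from compound 1 to compound 4 (0.53 log units; beyond the scatter), the only step that can be read among these compounds. It shows that the number responds to a change at this place, even though the two groups keep the same count of heavy atoms and the same ring type, and that compound 4 still gives a number rather than a limit. Nothing shown bears on the reason for this step.

The change alters both the halogen and its place on the ring, and the compounds shown leave open which of the two matters; 4-chlorophenyl or 2-fluorophenyl would separate them. On these data alone, how an unsubstituted phenyl or a 4-methoxyphenyl group would read at this place also remains open.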